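Notes on a nitro-benzopyran series: compound 4 from compound 2

The compounds below may be only part of what the source reports. "The series", "measured", "known", "first", "only" and "open" are said of these compounds alone.

Measured so far, with the largest response in a functional assay on the whole organism (aorta) with Rattus norvegicus as the target; on this read-out lower numbers stand for smaller maximal responses and higher numbers for larger maximal responses:
compound 1 `C/N=C(/S)C1=CC(C)(CF)Oc2ccc([N+](=O)[O-])cc21`: 77.1%
compound 2 `C/N=C(/S)C1=CC(C)(C(F)(F)F)Oc2ccc([N+](=O)[O-])cc21`: 62.5%
compound 3 `C/N=C(/S)C1=CC(C(F)(F)F)(C(F)(F)F)Oc2ccc([N+](=O)[O-])cc21`: 68%

Compound 2 stands at the lower end of these three numbers. The step of a number 14.6 percentage points lower from compound 1 to compound 2 (beyond the scatter) lies beyond the scatter; the step of a number 5.5 percentage points higher from compound 2 to compound 3 (within the scatter) does not, so compound 2 and compound 3 cannot be ordered. Compound 4 `CNC(=O)C1=CC(C)(C(F)(F)F)Oc2ccc([N+](=O)[O-])cc21` differs from compound 2 by a group of 4 heavy atoms (2 carbon, 1 nitrogen, 1 oxygen; no ring) in place of a group of 4 heavy atoms (2 carbon, 1 nitrogen, 1 sulfur; no ring), on a double-bonded ring carbon. Among the measured compounds shown here, both measured steps change groups on the saturated ring carbon, not the group on the double-bonded ring carbon, so neither bears directly on this change; the series offers no step of this kind. The expected step is therefore a number 0.5 percentage points lower from compound 2 to compound 4 (within the scatter), none beyond the scatter, with a wide range. For compound 4 the estimate in this assay is 62%, between 45% and 80%.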

Compound 4, intrinsic activity: the largest response reached, in percent of the reference agonist's: 61.7%
Compound 4: middle estimate off by 0.3 percentage points, on the high side; the range from low to high includes it.
By their numbers in this assay, from the lowest: compounds 4, 2, 3 and 1 (each within the scatter of the next, the first and the last beyond it).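

At the double-bonded ring carbon, the only step shown in this assay is methylcarbamoyl in place of the sulfur-bearing group, which gives a number 0.8 percentage points lower from compound 2 to compound 4 (within the scatter) and so no readable difference in maximal response. Among the compounds shown here, this is the first reading at this position, as both earlier steps changed the saturated ring carbon. Nothing available here bears on the reason for this result.

Going by these compounds, whether this holds with the saturated-carbon groups of compound 1 or compound 3 stays open. So does the response with an amine, a carboxylic acid or a nitrile at the double-bonded ring carbon.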